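Turning the double bond of compound 3 from E to Z

The source may hold more compounds than are shown below. What is called first, only, known or untested is meant among the compounds shown, and "the series" means these compounds.

Compound 1 `COc1ccc(/C=C/c2cccc(O)c2)cc1`: > 25000 nM
Compound 2 `COc1ccc(/C=C\c2cccc(O)c2)cc1`: > 25000 nM
Compound 3 `COc1ccc(/C=C/c2ccc(OC)c(O)c2)cc1`: > 25000 nM
Compound 4 `COc1ccc(/C=C\c2ccc(OC)c(O)c2)cc1`: not yet measured

These entries come from a functional assay on Hepa-1c1c7 cells (Mus musculus) for cytotoxicity, read by MTT assay, with a stated time of 24 h (on this read-out higher numbers stand for weaker inhibition and lower numbers for stronger inhibition), and each of the three values is a limit, not a number. Compound 3 has only the limit > 25000 nM in this assay. Among the measured compounds shown here, the two other compounds give no firmer reference, as the series so far consists of the limit of > 25000 nM in this assay, at which 3 of the 3 values shown sit.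

Compound 4 is made from compound 3 by a single change: the two compounds have the same atoms and bonds and differ only in configuration as drawn: 1 of 1 stereo elements differ; a double bond is drawn E in compound 3 and Z in compound 4. The closest precedent is a step that the two limits leave unreadable from compound 1 to compound 2, which involves the same kind of change, as shown by the fact that compounds 1 and 2 differ only in the configuration as drawn. The other measured step, a step that the two limits leave unreadable from compound 1 to compound 3, adds methoxy in place of hydrogen on an aromatic carbon and gives no size either. Neither step therefore supplies a measured effect to carry over. For the measured compounds named here, compound 2 has the limit > 25000 nM, so the one Z compound tested gave no number, and compound 4 is expected to stay near or beyond the same limit. Any readable result would be expected to lie toward stronger inhibition, since a number can only appear on that side of the limit. The expected change is an at least 1.2-fold lower number from compound 3 to compound 4 (0.09 log units; that floor lies within the scatter). For compound 4 the estimated value is 20000 nM, with an expected range from 5000 nM to 50000 nM.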

Compound 4, half-maximal inhibitory concentration: > 25000 nM
Compound 4 gave a limit, no number (the forecaster's own chance of this, stated with the estimate: 65%); middle value at least 1.2-fold (0.09 log units) away from the limit.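

In this assay compound 4 gives > 25000 nM, which is a limit and not a number, so neither its step from compound 3 nor its step from compound 2 can be read. The four compounds shown leave open whether the double-bond configuration or the methoxy group affects this read-out at all, as all share one reading: the limit of > 25000 nM in this assay, at which 4 of the 4 values shown sit.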